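The source may report more compounds than this note shows. Statements on the series, on what has been measured and on what is new or still open speak of the compounds shown alone.

Of the compounds shown here, two built on the same core have been tested in a functional assay on MDA-MB-231 cells (Homo sapiens) for cytotoxicity, read by MTT assay, with a stated time of 72 h; on this read-out lower numbers stand for stronger inhibition and higher numbers for weaker inhibition. Compound 1 `CN(C)CCNc1nc(-c2ccc(NC(=O)Nc3ccc(Cl)cc3Cl)cc2)nc2ccsc12` gives 2450 nM in this assay. Compound 2 `Cc1ccc(NC(=O)Nc2ccc(-c3nc(NCCN(C)C)c4sccc4n3)cc2)cc1` gives 2180 nM. For the measured compounds named here, the single measured step, a 1.1-fold lower number from compound 1 to compound 2 (0.05 log units; within the scatter), concerns a different part of the molecule, the group on the amide-type nitrogen. Going by the values given here, on the two numbers so far, compound 1 gives the higher one, though its gap to compound 2 lies within the scatter, so neither can be ranked against the other.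

Compound 3 `CCN(CC)CCNc1nc(-c2ccc(NC(=O)Nc3ccc(Cl)cc3Cl)cc2)nc2ccsc12` has not yet been measured. It differs from compound 1 in one place: diethylamino in place of dimethylamino on a saturated chain carbon, two bonds along the chain from a nitrogen on an aromatic ring. Among the compounds with values here, no measured step touches this position, so there is nothing in the numbers to suggest a change beyond the scatter in this assay. Compound 3 is therefore expected to give 2400 nM, within a range from 1000 nM to 6000 nM. That estimate means an expected step of a 1.0-fold lower number from compound 1 to compound 3 (0.01 log units; within the scatter).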

Compound 3, half-maximal inhibitory concentration: 2480 nM
For compound 3 the middle estimate is 1.0-fold (0.01 log units) below the measured one; measured number inside the range.
By their numbers in this assay, from the lowest: compounds 2, 1 and 3 (each within the scatter of the next).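

Diethylamino in place of dimethylamino, on a saturated chain carbon, two bonds along the chain from a nitrogen on an aromatic ring, now gives a first measured step at this position: in this assay, there is a 1.0-fold higher number from compound 1 to compound 3 (0.01 log units; within the scatter). The entering group has 5 heavy atoms against 3 for the one leaving, yet this assay does not tell the two apart, at least on the 2,4-dichlorophenyl compounds. No supporting evidence is available to explain this result.

Going by these compounds, it remains open whether a ring amine such as morpholine or piperidine, a primary amine, or a longer chain such as 3-(dimethylamino)propyl would also stay within the scatter here. The same change on the 4-methylphenyl compound also remains untested among the compounds shown.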